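A few compounds are considered here, and "the series" means these few. Any claim that something is new, unique, unknown or untested is made for them only; others in the source may bear on it.

Compound 1, `Cc1cc(C)c(Oc2cc(Nc3ccc(C#N)cc3)ncc2C(=O)NCc2cn(Cc3ccccc3C#N)nn2)c(C)c1`, was tested in an ADME assay on MT4 cells (Homo sapiens) for cytotoxicity, read by MTT assay, with a stated time of 5 days; on this read-out lower numbers stand for higher toxicity in this test and higher numbers for lower toxicity in this test. In that test compound 1 gives > 219000 nM, which is a limit of the assay rather than a measured number. Among the measured compounds shown here, its one measured neighbour, compound 2, `Cc1cc(C)c(Oc2cc(Nc3ccc(C#N)cc3)ncc2C(=O)NCc2cn(Cc3ccc(Cl)cc3)nn2)c(C)c1`, differs from it only by a 4-chlorophenyl in place of 2-cyanophenyl on a saturated chain carbon bound to an aromatic nitrogen. In this assay compound 2 gives >= 120000 nM, again a limit. The step that the two limits leave unreadable from compound 1 to compound 2 cannot be read, since both values sit at limits, as the limit of > 219000 nM in this assay, at which 1 of the 2 values shown sits, and the limit of >= 120000 nM in this assay, at which 1 of the 2 values shown sits, show. Compound 3, `CCOC(=O)CCn1cc(CNC(=O)c2cnc(Nc3ccc(C#N)cc3)cc2Oc2c(C)cc(C)cc2C)nn1`, carries a different change at the same place: (ethoxycarbonyl)methyl in place of 2-cyanophenyl on a saturated chain carbon bound to an aromatic nitrogen. For the measured compounds named here, the only measured step that bears on it has no readable size, so no shift beyond the scatter is expected; the step of an at least 1.0-fold lower number from compound 1 to compound 3 (0.03 log units; that floor lies within the scatter) is an estimate of no change. Compound 3 is therefore expected to show 200000 nM, within 100000 nM to 400000 nM.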

Compound 3, half-maximal cytotoxic concentration: 21500 nM
Estimate against measurement, compound 3: 9.3-fold (0.97 log units) above; the measured number lies below the stated range.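

In this assay, the place on a saturated chain carbon bound to an aromatic nitrogen now proves able to change the read-out: (ethoxycarbonyl)methyl in place of 2-cyanophenyl gives an at least 10-fold lower number from compound 1 to compound 3 (1.00 log units; beyond the scatter), and in place of 4-chlorophenyl it gives an at least 5.5-fold lower number from compound 2 to compound 3 (0.74 log units; beyond the scatter). A lower number here stands for higher toxicity in this test, and compound 3 is the first compound shown with a readable number rather than a limit. Each step starts from a limit and gives only a floor for its size.

Compound 3 loses the aromatic ring and gains the ethoxycarbonyl group in a single change, and the compounds shown do not separate the two. On these data alone, whether a carboxylic acid, a primary amide or a plain butyl chain at this place would also give a lower number remains open.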